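Replacing the oxolanyl group with methyl: tolerance in HEL cells

The compounds below may be only part of what the source reports. "The series", "measured", "known", "first", "only" and "open" are said of these compounds alone.

Compound 1 `CCCCCCC#Cc1cc2cn([C@H]3C[C@H](O)[C@@H](CO)O3)c(=O)nc2o1` — >= 97000 nM in a functional assay on HEL cells (Homo sapiens) for cytotoxicity (a lower number here means that less compound is tolerated, a higher number that more compound is tolerated), a limit of the assay rather than a number
Compound 2 `CCCCCCC#Cc1cc2cn([C@@H]3O[C@H](CO)[C@@H](O)[C@@H]3O)c(=O)nc2o1` — 133000 nM

Among the measured compounds shown here, compound 2 holds the only numerical value shown in this assay; the one other value is a limit. The step that the limit leaves unreadable from compound 1 to compound 2 is therefore unreadable, and compound 1 sits at the limit described by the limit of >= 97000 nM in this assay, at which 1 of the 2 values shown sits. The unmeasured compound 3 `CCCCCCC#Cc1cc2cn(C)c(=O)nc2o1` differs from compound 2 by methyl in place of 3,4-dihydroxy-5-(hydroxymethyl)oxolan-2-yl on an aromatic nitrogen. For the measured compounds named here, no measured step speaks to this change, since the single step recorded cannot be read. With compound 2 already at a high tolerated concentration, compound 3 is expected to lie in the same region, with an estimated step of a 1.3-fold lower number from compound 2 to compound 3 (0.12 log units; within the scatter) that need not exceed the scatter. The estimate for compound 3 is 100000 nM, within 30000 nM to 300000 nM.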

Compound 3, minimum cytotoxic concentration: 194000 nM
Beside the measured number, compound 3's estimate is 1.9-fold (0.29 log units) below it; low and high end bracket the measured number.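

In this assay, the change on the aromatic nitrogen gives a 1.5-fold higher number from compound 2 to compound 3 (0.16 log units; within the scatter), so the exchange of 3,4-dihydroxy-5-(hydroxymethyl)oxolan-2-yl for methyl does not separate the two compounds. Among the compounds shown here, this is the first readable step, and it shows that a group of 9 heavy atoms with 3 hydrogen-bond donors and 4 defined stereocentres can give way to a single carbon with no change beyond the scatter. The steps from compound 1 cannot be read, because compound 1 stands at a limit rather than a number: the limit of >= 97000 nM in this assay, at which 1 of the 3 values shown sits.

As far as these compounds go, whether this tolerance of change extends to other groups on that nitrogen remains open, for instance an aminoethyl group, a carboxylic acid or a longer alkyl chain. Also open, from the compounds shown here alone, is whether any group there could move the number beyond the scatter in this assay.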